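The source may report more compounds than this note shows. Statements on the series, on what has been measured and on what is new or still open speak of the compounds shown alone.

Measured so far in an assay on NIH3T3 cells with Urotensin-2 receptor (Homo sapiens) as the target; a lower number here means that less compound is needed, a higher number that more compound is needed for the effect:
Compound 1 `Cc1ccccc1C(=O)NC(CCN(C)C)c1ccc(Cl)cc1` gives 3550 nM.
Compound 2 `COc1cccc(C(=O)NC(CCN(C)C)c2ccc(Cl)cc2)c1C` gives 4270 nM.
Compound 3 `Cc1c(Cl)cccc1C(=O)NC(CCN(C)C)c1ccc(Cl)cc1` gives 1740 nM.

Compound 3 stands lowest of the three numbers. Its nearest neighbour is compound 1, with a gap of a 2.0-fold lower number from compound 1 to compound 3 (0.31 log units; beyond the scatter), and the wider gap is a 2.5-fold lower number from compound 2 to compound 3 (0.39 log units; beyond the scatter). Compound 4 `Cc1ccc(C(=O)NC(CCN(C)C)c2ccc(Cl)cc2)c(C)c1` differs from compound 3 in one place: 2,4-dimethylphenyl in place of 3-chloro-2-methylphenyl on a carbonyl carbon. Both measured steps bear on this change, since each alters the same aromatic ring on the carbonyl carbon. The step of a 1.2-fold higher number from compound 1 to compound 2 (0.08 log units; within the scatter) shows that one exchange on that ring left the number essentially unchanged, whereas the chloro of compound 3 brought a modest gain over compound 1. Compound 4 gives up that chloro and carries a second methyl instead, so a small upward step, expected as a 1.5-fold higher number from compound 3 to compound 4 (0.17 log units; within the scatter) in this assay, seems likely but is not assured beyond the scatter. Compound 4 is therefore estimated at 2600 nM, with a range from 1100 nM to 6000 nM.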

Compound 4, half-maximal effective concentration: 1550 nM
Estimate against measurement, compound 4: 1.7-fold (0.22 log units) above, and the stated range covers the measured number.
By their numbers in this assay, from the lowest: compounds 4 and 3 (each within the scatter of the next); then compounds 1 and 2 (each within the scatter of the next).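

In this assay, replacing 3-chloro-2-methylphenyl with 2,4-dimethylphenyl on the carbonyl carbon leaves the number within the scatter (a 1.1-fold lower number from compound 3 to compound 4 (0.05 log units; within the scatter)), so among these compounds the chloro of compound 3 is not required to hold this level. The added methyl also gives a modest step of its own (a 2.3-fold lower number from compound 1 to compound 4 (0.36 log units; beyond the scatter)), which shows that a chloro is not the only substituent on this ring that can improve on compound 1. No measurement here accounts for these two rings reading alike.

The compounds shown leave open whether a single methyl, as in 4-methylphenyl, would give the same reading without the 2-methyl group. They also leave open how this ring would respond to an amine, a carboxylic acid or a longer alkyl chain.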